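A few compounds are considered here, and "the series" means these few. Any claim that something is new, unique, unknown or untested is made for them only; others in the source may bear on it.

In a functional assay on MCF7 cells (Homo sapiens) for inhibition, read by MTT assay, with a stated time of 48 h, tested at 10 uM (a higher number here means more inhibition of growth at the concentration tested, a lower number less inhibition of growth), compound 1 (`Cc1cc(=O)c2c(O)c(CN(C)CC(=O)O)c(O)c([C@H]3CCN(C)C[C@H]3O)c2o1`) gives 27% and compound 2 (`Cc1oc2c([C@H]3CCN(C)C[C@H]3O)c(O)cc(O)c2c(=O)c1C(O)c1ccc(Cl)cc1`) gives 6%. Compound 2 holds the lower of these two numbers, and its gap to compound 1 lies beyond the usual scatter. Compound 3 (`Cc1oc2c([C@H]3CCN(C)C[C@H]3O)c(O)cc(O)c2c(=O)c1C(O)c1c(Cl)cccc1Cl`) has not yet been measured. It carries 2,6-dichlorophenyl in place of 4-chlorophenyl on a saturated chain carbon bound to an aromatic carbon and an oxygen on a saturated carbon. Among the measured compounds shown here, no measured pair differs in a single place, so the data do not size this change directly. The expectation therefore starts from compound 2 at 6% in this assay, with no shift beyond the scatter. The expected step is a number 4 percentage points higher from compound 2 to compound 3 (within the scatter), a small rise that would stay within the scatter. For compound 3 the estimated value is 10%, with an expected range from 0% to 25%.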

Compound 3, percent growth inhibition at one concentration: 33%
For compound 3 the middle estimate is 23 percentage points below the measured one; the whole stated range lies below it.
By their numbers in this assay, from the lowest: compound 2; then compounds 1 and 3 (each within the scatter of the next).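

In this assay, putting 2,6-dichlorophenyl in place of 4-chlorophenyl on the saturated chain carbon bound to an aromatic carbon and an oxygen on a saturated carbon gives a number 27 percentage points higher from compound 2 to compound 3 (beyond the scatter). This is the first change in a single place among the compounds shown, and it establishes that inhibition of growth at the concentration tested depends on which chlorinated phenyl group sits at this position, with the rest of the structure held constant. No measurement is available that accounts for the size of this step.

The compounds shown leave open how plain phenyl, or a phenyl ring carrying methoxy or an amine, would fare at this position. They also leave open whether the step would persist if a carboxylic acid replaced the hydroxy group on the chain carbon.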